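The source may report more compounds than this note shows. Statements on the series, on what has been measured and on what is new or still open speak of the compounds shown alone.

Working notes on the series. Compound 1 `CC(C)c1ccc(-c2nc(SCc3cn(CC(=O)NC(=O)Nc4ccccn4)nn3)nc(Nc3ccccc3)c2C#N)cc1` in a functional assay on ECa-109 cells (Homo sapiens) for inhibition, read by MTT assay, with a stated time of 72 h (a higher number here means a weaker inhibitor, a lower number a stronger inhibitor), gives > 64000 nM, which is a limit of the assay and not a number. Within the data shown here, compound 2 `COc1ccc(Nc2nc(SCc3cn(CC(=O)NC(=O)Nc4ccccn4)nn3)nc(-c3ccc(C(C)C)cc3)c2C#N)cc1` in this assay gives 5420 nM; it is the only number among the values. The value of compound 1 is a limit (the limit of > 64000 nM in this assay, at which 1 of the 2 values shown sits). Among the measured compounds shown here, the one measured step, an at least 11-fold lower number from compound 1 to compound 2 (1.07 log units; beyond the scatter), is methoxy in place of hydrogen on an aromatic carbon. Compound 3 `CC(C)c1ccc(-c2nc(SCc3cn(CC(=O)NC(=O)Nc4ccccn4)nn3)nc(Nc3ccccc3O)c2C#N)cc1` differs from compound 2 by 2-hydroxyphenyl in place of 4-methoxyphenyl on a nitrogen on an aromatic ring. For the measured compounds named here, the measured step bears on this only in part: the methoxy that marked the gain from compound 1 to compound 2 leaves, and a hydroxyl enters, for which no measured step exists. Compound 3 is therefore expected to move toward the weaker side, by a step of a 4.6-fold higher number from compound 2 to compound 3 (0.66 log units; beyond the scatter), with a real chance that only a limit is returned. The estimate for compound 3 in this assay is 25000 nM, between 6000 nM and 64000 nM.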

Compound 3, half-maximal inhibitory concentration: 7380 nM
The estimate for compound 3 lay 3.4-fold (0.53 log units) above the measured number; the range from low to high includes it.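

On the nitrogen on an aromatic ring, 2-hydroxyphenyl and 4-methoxyphenyl cannot be told apart in this assay (a 1.4-fold higher number from compound 2 to compound 3 (0.13 log units; within the scatter)). Compared with the plain phenyl of compound 1, the hydroxy change gives a second step beyond the scatter (an at least 8.6-fold lower number from compound 1 to compound 3 (0.93 log units; beyond the scatter)), so the gain is no longer tied to methoxy alone. From the compounds shown here alone, the value of compound 1 is a limit and not a number, so the full size of this step stays unknown: the limit of > 64000 nM in this assay, at which 1 of the 3 values shown sits.

Compound 2 and compound 3 differ in both the group and its place on the ring, so the effect of either one alone cannot be separated. Going by these compounds, it also remains open whether an oxygen on that ring is needed at all, and how a 4-aminophenyl or a 4-chlorophenyl would read on the same nitrogen.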